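A Modest Aryl Swap on an Imine Nitrogen

The source may report more compounds than this note shows. Statements on the series, on what has been measured and on what is new or still open speak of the compounds shown alone.

Compound 1, `O=C1Nc2ccc(S(=O)(=O)N3CCOCC3)cc2/C1=N/c1ccc(Br)cc1`, is measured in an ADME assay on WI-38 cells (Homo sapiens) for cytotoxicity, read by sulforhodamine B assay, with a stated time of 24 h (on this read-out higher numbers stand for weaker inhibition and lower numbers for stronger inhibition), where compound 1 gives 372000 nM. Compound 3, `O=C1Nc2ccc(S(=O)(=O)N3CCOCC3)cc2/C1=N/NC(=O)c1ccccc1`, gives 295000 nM in this assay, and the change a 1.3-fold lower number from compound 1 to compound 3 (0.10 log units; within the scatter) is within the scatter. Compound 2, `COc1ccc(-c2c(C#N)c(N)n(/N=C3\C(=O)Nc4ccc(S(=O)(=O)N5CCOCC5)cc43)c(=O)c2C#N)cc1`, gives 224000 nM in this assay. Compound 1 thus stands at the top of the three numbers, but neither its gap to compound 3 nor its gap to compound 2 exceeds the usual scatter, so the three compounds cannot be told apart on this read-out.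

Compound 4, `CC(=O)c1cccc(/N=C2\C(=O)Nc3ccc(S(=O)(=O)N4CCOCC4)cc32)c1`, differs from compound 1 by 3-acetylphenyl in place of 4-bromophenyl on a double-bonded nitrogen. Among the measured compounds shown here, the only measured step touching this position is the one from compound 1 to compound 3, which changes the group on the same double-bonded nitrogen and stays within the scatter. The step in this assay from compound 1 to compound 4 is therefore expected to be small, a 1.1-fold lower number from compound 1 to compound 4 (0.05 log units; within the scatter), with no clear direction. Compound 4 is estimated at 330000 nM, in a range from 150000 nM to 700000 nM.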

Compound 4, half-maximal inhibitory concentration: 177000 nM
For compound 4 the middle estimate is 1.9-fold (0.27 log units) above the measured one; low and high end bracket the measured number.
By their numbers in this assay, from the lowest: compounds 4, 2, 3 and 1 (each within the scatter of the next, the first and the last beyond it).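

Among the compounds shown here, on this double-bonded nitrogen, the group can move the number in this assay beyond the scatter, though only modestly: 3-acetylphenyl in place of 4-bromophenyl gives a 2.1-fold lower number from compound 1 to compound 4 (0.32 log units; beyond the scatter) as the first step at this position to clear it. The group entering here need not differ from every other group, however, as 3-acetylphenyl in place of benzamido gives a 1.7-fold lower number from compound 3 to compound 4 (0.22 log units; within the scatter) and leaves those two compounds unseparated on this read-out. No measurement shown here accounts for the step from 4-bromophenyl to 3-acetylphenyl.

As far as these compounds go, it remains open whether the acetyl group itself matters or whether an unsubstituted phenyl would give a similar number. The compounds also leave open how an amine or a carboxylic acid on this phenyl ring would fare in this assay on the same read-out.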